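The source may report more compounds than this note shows. Statements on the series, on what has been measured and on what is new or still open speak of the compounds shown alone.

Measured in a functional assay on MCF7 cells (Homo sapiens) for antiproliferative activity, read by MTT assay, with a stated time of 48 h; a higher number here means a weaker inhibitor, a lower number a stronger inhibitor:
compound 1 `Cc1cccc(-n2nncc2CN2C(=O)C3(C(C#N)=C(N)Oc4c3c3nc5ccccc5nc3c3ccccc43)c3ccccc32)c1` — > 50000 nM
compound 2 `N#CC1=C(N)Oc2c(c3nc4ccccc4nc3c3ccccc23)C12C(=O)N(Cc1cnnn1-c1ccc(Br)cc1)c1ccccc12` — 36600 nM
compound 3 `COc1ccccc1-n1nncc1CN1C(=O)C2(C(C#N)=C(N)Oc3c2c2nc4ccccc4nc2c2ccccc32)c2ccccc21` — > 50000 nM

The value for compound 3 is a limit of the assay, not a number. The same holds across the set, see (the limit of > 50000 nM in this assay, at which 2 of the 3 values shown sit). Compound 3 therefore stands at the weak end of what this assay resolves, with no number to anchor it.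

The change to compound 4 `N#CC1=C(N)Oc2c(c3nc4ccccc4nc3c3ccccc23)C12C(=O)N(Cc1cnnn1-c1cccc(S(N)(=O)=O)c1)c1ccccc12` is 3-sulfamoylphenyl in place of 2-methoxyphenyl on an aromatic nitrogen. The measured steps that bear on it all alter the aryl group on the same nitrogen of the five-membered aromatic ring with 3 nitrogen: a step that the two limits leave unreadable from compound 1 to compound 3, an at least 1.3-fold higher number from compound 2 to compound 3 (0.13 log units; that floor lies within the scatter) and an at least 1.3-fold lower number from compound 1 to compound 2 (0.13 log units; that floor lies within the scatter). Each is bounded by the limit, and none is shown to exceed the scatter. Within these three compounds, exchanging the aryl group has not moved the read-out in a readable way.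

For compound 4 no step beyond the scatter is expected, a number no higher from compound 3 to compound 4 (the limit leaves the size open). Compound 4 is estimated at 50000 nM, range 25000 nM to 120000 nM, with a sizeable chance that only a limit is returned.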

Compound 4, half-maximal inhibitory concentration: 42500 nM
Compound 4: the middle estimate sits 1.2-fold (0.07 log units) above what was measured; the measured number falls inside the stated range.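

In this assay compound 4 gives 42500 nM, a number and not a limit, so this aryl position now has a second group with a real reading. Between the two groups that give numbers there is a 1.2-fold higher number from compound 2 to compound 4 (0.06 log units; within the scatter); 3-sulfamoylphenyl, with its hydrogen-bond donor, and 4-bromophenyl therefore read alike. Against the two limits the result gives only floors, an at least 1.1-fold lower number from compound 3 to compound 4 (0.07 log units; that floor lies within the scatter) and an at least 1.1-fold lower number from compound 1 to compound 4 (0.07 log units; that floor lies within the scatter), so no step at this position is yet shown beyond the scatter: the limit of > 50000 nM in this assay, at which 2 of the 4 values shown sit.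

As far as these compounds go, how a carboxylic acid or an amine on the phenyl ring, or a longer chain in place of the aryl group, would read remains open. Also open, from the compounds shown here alone, is whether any change to the shared core would move the read-out beyond the scatter.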